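A few compounds are considered here, and "the series" means these few. Any claim that something is new, unique, unknown or untested is made for them only; others in the source may bear on it.

Measured so far in a functional assay on Daoy cells (Homo sapiens) for cytotoxicity, read by MTT assay, with a stated time of 72 h; a higher number here means a weaker inhibitor, a lower number a stronger inhibitor:
compound 1 `COc1cc(NC(=O)c2ccc(F)cc2)cc(OC)c1OC`: >= 125000 nM
compound 2 `COc1cc(NC(=O)c2ccc([N+](=O)[O-])cc2)cc(OC)c1OC`: 52900 nM
compound 3 `COc1cc(NC(=O)Nc2ccc(O)c3ccccc23)cc(OC)c1OC`: 100 nM

The value for compound 1 is a limit of the assay and not a measured number; that limit is the limit of >= 125000 nM in this assay, at which 1 of the 3 values shown sits. Going by the values given here, the only step measured between compounds that differ in one place is an at least 2.3-fold lower number from compound 1 to compound 2 (0.37 log units; beyond the scatter), and it concerns the aromatic ring, not the amide. Among the compounds with values here, compound 3 differs from compound 1 in more than one place, so no single step connects it to the others.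

Compound 4 `COc1cc(N(C)C(=O)c2ccc(F)cc2)cc(OC)c1OC` differs from compound 1 in one place: methyl in place of hydrogen on an amide-type nitrogen. Within the data shown here, no measured step touches the amide nitrogen, so nothing among the data sets a size or direction for this change, and compound 1 itself sits at a limit. The expected step is therefore none beyond the scatter: a number no higher from compound 1 to compound 4 (the limit leaves the size open). Compound 4 is estimated at 125000 nM in this assay, with a range from 50000 nM to 300000 nM.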

Compound 4, half-maximal inhibitory concentration: >= 125000 nM
Compound 4: a limit, no number; the forecaster's own chance of this, stated with the estimate: 70%; the middle value lies on the limit itself.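

Compound 1 and compound 4 both give a limit and not a number, so no step can be read for methyl in place of hydrogen on the amide-type nitrogen: the limit of >= 125000 nM in this assay, at which 2 of the 4 values shown sit.

The compounds shown leave open whether this methyl changes the number at all, in either direction.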